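Bromo substitution on the core of compound 3

The source may report more compounds than this note shows. Statements on the series, on what has been measured and on what is new or still open speak of the compounds shown alone.

Three sulfonamides on related cores have numbers in a functional assay on A549 cells (Homo sapiens) for cytotoxicity, read by MTT assay, with a stated time of 72 h; a lower number here means a stronger inhibitor, a higher number a weaker inhibitor. Compound 1 `Cc1ccc(S(=O)(=O)Nc2cccc3[nH]nc(Br)c23)cc1` gives 82400 nM. Compound 2 `COc1ccc(S(=O)(=O)Nc2cccc3[nH]nc(Cl)c23)cc1` gives 1830 nM. Compound 3 `CCOc1ccc(NS(=O)(=O)c2ccc(C)cc2)c2cn[nH]c12` gives 58500 nM, the second highest of the three: its gap to compound 1 lies within the scatter, its gap to compound 2 beyond it.

Compound 4 `CCOc1ccc(NS(=O)(=O)c2ccc(C)cc2)c2c(Br)n[nH]c12` differs from compound 3 by bromo in place of hydrogen on an aromatic carbon. For the measured compounds named here, no measured pair isolates this change; compound 1 and compound 2 carry halogens on the same position of the core but differ elsewhere, so they do not settle the step.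

The step from compound 3 to compound 4 is expected to be small, a 2.0-fold lower number from compound 3 to compound 4 (0.29 log units; within the scatter), toward a lower number but possibly within the scatter. Compound 4 is estimated at 30000 nM, with a range from 8000 nM to 120000 nM.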

Compound 4, half-maximal inhibitory concentration: 17500 nM
For compound 4 the middle estimate is 1.7-fold (0.23 log units) above the measured one, within the range that was stated.
By their numbers in this assay, from the lowest: compound 2; then compound 4; then compounds 3 and 1 (each within the scatter of the next).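

In this assay, bromo in place of hydrogen on this aromatic carbon of the five-membered ring now has a single-change pair, with a 3.3-fold lower number from compound 3 to compound 4 (0.52 log units; beyond the scatter) as its step. For the compounds shown here, with bromo held in place, adding an ethoxy group as the single change points the same way, with a 4.7-fold lower number from compound 1 to compound 4 (0.67 log units; beyond the scatter) as its step. Nothing available gives a cause for either step.

As far as these compounds go, whether an amine or a carboxylic acid on the bromo-bearing carbon would move the number in the same direction stays open. So does whether a longer chain in place of ethoxy would keep the second step.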